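Swapping a difluorophenyl for a chlorophenyl on the piperazine

The source may report more compounds than this note shows. Statements on the series, on what has been measured and on what is new or still open speak of the compounds shown alone.

Measured so far:
compound 1 `Nc1scc(CN2CCN(C3CCCCCC3)CC2)c1C(=O)c1ccc(Cl)cc1` gives 2.9%;
compound 2 `Nc1scc(CN2CCN(c3cccc(F)c3)CC2)c1C(=O)c1ccc(Cl)cc1` gives -18%;
compound 3 `Nc1scc(CN2CCN(c3cc(F)cc(F)c3)CC2)c1C(=O)c1ccc(Cl)cc1` gives -13%.

All three share one core and differ only in the group on an amine nitrogen in a ring. In a functional assay on CHO cells with adenosine receptor A1 (Homo sapiens) as the target, read by cAMP accumulation and immunoassay, with a stated time of 6 min, tested at 0.01 uM (on this read-out lower numbers stand for a stronger effect and higher numbers for a weaker effect at the one concentration tested), compound 3 stands second highest of the three numbers. Its nearest neighbour is compound 2, and the step of a number 5 percentage points higher from compound 2 to compound 3 (within the scatter) lies within the scatter, so the two cannot be ordered. Its furthest neighbour is compound 1, and the step of a number 15.9 percentage points lower from compound 1 to compound 3 (beyond the scatter) is beyond the scatter, as is the related step of a number 20.9 percentage points lower from compound 1 to compound 2 (beyond the scatter).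

Compound 4 `Nc1scc(CN2CCN(c3cccc(Cl)c3)CC2)c1C(=O)c1ccc(Cl)cc1` is not yet measured. The change from compound 3 is 3-chlorophenyl in place of 3,5-difluorophenyl on an amine nitrogen in a ring. Going by the values given here, no measured step exchanges a chloro for fluoro groups, so the only guide is that a fluoro for hydrogen on the same ring gave a number 5 percentage points higher from compound 2 to compound 3 (within the scatter), a change within the scatter. For compound 4 the expected step is therefore no change at the digits printed from compound 3 to compound 4 (within the scatter), not beyond the scatter. Compound 4 is estimated at -13%, with a range from -30% to 5%.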

Compound 4, a percentage reported as activity, at one concentration (the size of the read-out at that concentration, not a potency): -3.1%
The estimate for compound 4 lay 9.9 percentage points below the measured number, within the range that was stated.
By their numbers in this assay, from the lowest: compounds 2, 3, 4 and 1 (each within the scatter of the next, the first and the last beyond it).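

In this assay, going by these compounds alone, chloro in place of fluoro on the aromatic ring gives a number 14.9 percentage points higher from compound 2 to compound 4 (beyond the scatter), the first change of halogen on this ring that can be read beyond the scatter, and so the choice of halogen on this phenyl group can matter. The other two steps are smaller: 3-chlorophenyl in place of 3,5-difluorophenyl gives a number 9.9 percentage points higher from compound 3 to compound 4 (within the scatter), and 3-chlorophenyl in place of cycloheptyl gives a number 6 percentage points lower from compound 1 to compound 4 (within the scatter), so compound 4 cannot be told apart from either compound 3 or compound 1, even though those two differ beyond the scatter. No evidence here explains these differences.

The compounds shown leave open how a bromophenyl or a methoxyphenyl group on this ring nitrogen would read. They also leave open whether these differences would hold at other concentrations, since a single-concentration read-out is not a potency.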